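Cyano for methoxy: cytotoxicity in the nitrobenzyl piperidine series

This account rests on a few compounds, and the source may have more. Where it says the series, first, only, none or still open, it means among the compounds named here.

Measured so far:
compound 1 `O=[N+]([O-])c1ccc(CN2CCC(n3cc(CC(OCc4cc(-c5ccccc5)no4)c4ccc(Br)cc4)nn3)CC2)cc1` — in an ADME assay on cells (Fibroblast, Homo sapiens) for cytotoxicity, with a stated time of 48 h (on this read-out higher numbers stand for weaker inhibition and lower numbers for stronger inhibition), compound 1 gives > 25000 nM, a limit of the assay.
compound 2 `COc1ccc(-c2cc(COC(Cc3cn(C4CCN(Cc5ccc([N+](=O)[O-])cc5)CC4)nn3)c3ccc(Br)cc3)on2)cc1` — in this assay compound 2 gives > 25000 nM, likewise a limit of the assay.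

Compound 2 thus stands at the limit, and nothing finer than that is seen for it. The shared evidence is the limit of > 25000 nM in this assay, at which 2 of the 2 values shown sit. Going by the values given here, the only step measured so far, a step that the two limits leave unreadable from compound 1 to compound 2, is methoxy in place of hydrogen on an aromatic carbon; its size cannot be read.

Compound 3 `N#Cc1ccc(-c2cc(COC(Cc3cn(C4CCN(Cc5ccc([N+](=O)[O-])cc5)CC4)nn3)c3ccc(Br)cc3)on2)cc1` differs from compound 2 by cyano in place of methoxy on an aromatic carbon. The step from compound 1 to compound 2 touches the same aromatic ring, but with both ends sitting at the limit it gives no readable size to carry over. No step beyond the scatter is therefore expected for a step that the limit leaves unreadable from compound 2 to compound 3, and compound 3 is expected to return a limit again in this assay.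

Compound 3 is estimated at 35000 nM, with a range from 10000 nM to 120000 nM.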

Compound 3, half-maximal inhibitory concentration: > 25000 nM
Compound 3 was reported as a limit (the forecaster's own chance of this, stated with the estimate: 80%); the middle value is on the limit's open side.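

Going by these compounds, no new step can be read: the steps among compound 1, compound 2 and compound 3 all run between limits, so their sizes stay unknown. The evidence remains a shared limit: the limit of > 25000 nM in this assay, at which 3 of the 3 values shown sit.

The compounds shown leave open whether hydrogen, methoxy or cyano on that aromatic ring makes any difference in this assay.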